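A few compounds are considered here, and "the series" means these few. Any claim that something is new, unique, unknown or untested is made for them only; others in the source may bear on it.

Three measured compounds share one core, and in an assay on isolated protein for binding affinity to secreted frizzled-related protein 1 (Homo sapiens), read by fluorescence (a lower number here means a stronger inhibitor, a higher number a weaker inhibitor), compound 1 `O=C(CN1CCCC1)N1CCC(NS(=O)(=O)c2cc(S(=O)(=O)c3ccccc3)ccc2C(F)(F)F)CC1` gives 110 nM. Compound 2 `CC(C)(C)OC(=O)N1C(=O)CC[C@H]1C(=O)N1CCC(NS(=O)(=O)c2cc(S(=O)(=O)c3ccccc3)ccc2C(F)(F)F)CC1` gives 130 nM in this assay, and compound 3 `CC(=O)N1CCC[C@H]1C(=O)N1CCC(NS(=O)(=O)c2cc(S(=O)(=O)c3ccccc3)ccc2C(F)(F)F)CC1` gives 160 nM. Compound 3 therefore stands apart from neither companion: its gap to compound 2 and its gap to compound 1 both lie within the scatter, so the three numbers describe one level rather than a ranking.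

Compound 4 `O=C([C@@H]1CCCN1C(=O)Nc1ccccc1)N1CCC(NS(=O)(=O)c2cc(S(=O)(=O)c3ccccc3)ccc2C(F)(F)F)CC1` differs from compound 3 by anilino in place of methyl on a carbonyl carbon. Among the measured compounds shown here, the one measured step that bears on this part of the molecule is a 1.5-fold higher number from compound 1 to compound 3 (0.16 log units; within the scatter), a change on the same carbonyl carbon that stayed within the scatter, and compound 2, which carries yet another group in this region, also lands close to compound 3. Nothing measured suggests that this end of the molecule moves the number strongly in either direction, so he expects a step of a 1.1-fold lower number from compound 3 to compound 4 (0.03 log units; within the scatter), not beyond the scatter. On that basis compound 4 is estimated at 150 nM, within a range of 60 nM to 400 nM.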

Compound 4, half-maximal inhibitory concentration: 20 nM
Compound 4: middle estimate off by 7.5-fold (0.88 log units), on the high side; the whole stated range lies above it.
By their numbers in this assay, from the lowest: compound 4; then compounds 1, 2 and 3 (each within the scatter of the next).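

Replacing methyl with anilino on this carbonyl carbon, whose other neighbour is an amide-type nitrogen in a ring, gives an 8.0-fold lower number from compound 3 to compound 4 (0.90 log units; beyond the scatter) in this assay, and this is the only step shown that lies beyond the scatter. The earlier compounds shown here sat at one level and made this end of the molecule look flat, but compound 4 shows that the number does respond to the group placed here. The change brings in a six-membered aromatic ring and a hydrogen-bond donor together, so the step cannot be assigned to either one alone, and no measurement shown accounts for the result.

A phenoxy group on this carbonyl carbon would keep the ring without the amide hydrogen, and a cyclohexylamino group would keep the amide hydrogen without the aromatic ring. From the compounds shown here alone, whether a chloro or methoxy group on the anilino ring would shift the number further also remains open.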